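The source may report more compounds than this note shows. Statements on the series, on what has been measured and on what is new or still open speak of the compounds shown alone.

Compounds measured so far:
- compound 1 `Cc1ccc(Nc2nc(Cl)nc3c2ncn3Cc2ccc(C(=O)Nc3ccccc3N)cc2)cc1`, in a functional assay on NCI-H460 cells (Homo sapiens) for antiproliferative activity, read by CCK-8 assay, with a stated time of 72 h (on this read-out higher numbers stand for weaker inhibition and lower numbers for stronger inhibition), compound 1 gives 1590 nM
- compound 2 `Nc1ccccc1NC(=O)c1ccc(Cn2cnc3c(Nc4ccccc4)nc(Cl)nc32)cc1`, in this assay compound 2 gives 5740 nM
- compound 3 `Nc1ccccc1NC(=O)c1ccc(Cn2cnc3c(Nc4ccc(-c5ccccn5)cc4)nc(Cl)nc32)cc1`, in this assay compound 3 gives 18400 nM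

Compound 3 stands highest of the three in this assay. Its nearest neighbour is compound 2, and the step is a 3.2-fold higher number from compound 2 to compound 3 (0.51 log units; beyond the scatter). The widest gap separates it from compound 1, as a 12-fold higher number from compound 1 to compound 3 (1.06 log units; beyond the scatter) shows. The step of a 3.6-fold higher number from compound 1 to compound 2 (0.56 log units; beyond the scatter) completes the picture among the measured compounds.

Compound 4 `Nc1ccccc1NC(=O)c1ccc(Cn2cnc3c(Nc4cccc(Cl)c4)nc(Cl)nc32)cc1` differs from compound 3 in one place: 3-chlorophenyl in place of 4-(pyridin-2-yl)phenyl on a nitrogen on an aromatic ring. Going by the values given here, the steps that bear on this change are those that already altered the same ring. The step of a 3.2-fold higher number from compound 2 to compound 3 (0.51 log units; beyond the scatter) shows that bringing the pyridin-2-yl group in raised the number modestly, so taking it away again is expected to bring the number back down toward the region of compound 2. Whether the chlorine that enters moves the number further in either direction cannot be read from the measured compounds, since no chlorine on this ring has been examined. The expected step for compound 4 is therefore a modest one downward, a 3.7-fold lower number from compound 3 to compound 4 (0.57 log units; beyond the scatter). In this assay compound 4 is expected to give about 5000 nM, in the range from 1500 nM to 16000 nM.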

Compound 4, half-maximal inhibitory concentration: 6580 nM
For compound 4 the middle estimate is 1.3-fold (0.12 log units) below the measured one, and the stated range covers the measured number.
By their numbers in this assay, from the lowest: compound 1; then compounds 2 and 4 (each within the scatter of the next); then compound 3.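

In this assay, the step of a 1.1-fold higher number from compound 2 to compound 4 (0.06 log units; within the scatter) shows that chloro in place of hydrogen on this aromatic ring does not separate 3-chlorophenyl from the plain phenyl of compound 2, so this ring can carry a chlorine without a readable change in the number. The step of a 2.8-fold lower number from compound 3 to compound 4 (0.45 log units; beyond the scatter) shows that exchanging 4-(pyridin-2-yl)phenyl for this smaller group on the nitrogen undoes the rise seen with the pyridin-2-yl group, while the step of a 4.1-fold higher number from compound 1 to compound 4 (0.62 log units; beyond the scatter) shows that 3-chlorophenyl does not match 4-methylphenyl, which keeps compound 1 lowest of the four, with steps beyond the scatter to each of the others. Nothing shown gives a reason for any of these steps.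

The compounds shown leave open whether the low number of compound 1 belongs to methyl itself or to where it sits, and 3-methylphenyl and 4-chlorophenyl would each separate those two readings. Also open, from the compounds shown here alone, is how other groups on this ring, such as a methoxy, an amine or a longer alkyl chain, would fall relative to methyl and chloro.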